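The source may report more compounds than this note shows. Statements on the series, on what has been measured and on what is new or still open speak of the compounds shown alone.

Compound 1 `COc1ccc(/C=C/C(=O)NC(CCN(C)C)c2ccc(C)cc2)cc1`, 79%; compound 2 `COc1ccc(/C=C/C(=O)NC(CCN(C)C)c2ccc(Cl)cc2)cc1`, 99%; compound 3 `COc1ccc(CCC(=O)NC(CCN(C)C)c2ccc(Cl)cc2)cc1`, 101%.

In a functional assay on NIH3T3 cells for agonist activity at Urotensin-2 receptor (Homo sapiens), with a stated time of 5 days (a higher number here means a larger maximal response, a lower number a smaller maximal response), compound 3 gives 101% and compound 2 gives 99%, two numbers that lie within the scatter of each other; the difference between the cores of compound 2 and compound 3 is not broken down here. Compound 1 sits lower: the change methyl in place of chloro on an aromatic carbon makes a number 20 percentage points lower from compound 2 to compound 1 (beyond the scatter). Compound 4 `COc1ccc(CCC(=O)NC(CCN(C)C)c2ccc(C)cc2)cc1` is not yet measured; it differs from compound 3 by methyl in place of chloro on an aromatic carbon, the same change as that from compound 2 to compound 1, now made on the core of compound 3. Because compound 3 starts at 101% and because the same change made a number 20 percentage points lower from compound 2 to compound 1 (beyond the scatter), compound 4 is expected to show a step of about a number 20 percentage points lower from compound 3 to compound 4 (beyond the scatter) in this assay. Compound 4 is therefore estimated at 81% in this assay, with a likely range from 66% to 96%.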

Compound 4, largest response reached (reported as efficacy), in percent of the reference or control that the assay uses: 67%
Compound 4: middle estimate off by 14 percentage points, on the high side; measured number inside the range.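

In this assay, methyl in place of chloro again lowers the maximal response, giving a number 34 percentage points lower from compound 3 to compound 4 (beyond the scatter). Set beside the earlier step, the new one points the same way and cannot be told apart from it in size: the same change on two cores in this assay, a number 20 percentage points lower (beyond the scatter) from compound 2 to compound 1 and a number 34 percentage points lower (beyond the scatter) from compound 3 to compound 4, 14 percentage points apart, within the scatter of two such steps. This shows that the change carried over from one core to the other in direction and, within the scatter, in size, but two cores cannot show that it would do so on any other core in the series, and the numbers do not say why the response falls.

The compounds shown leave open how a fluoro, bromo or methoxy group would behave at the same place on the ring. They also leave open whether the step would persist if the dimethylamino group gave way to a primary amine.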